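The compounds below may be only part of what the source reports. "The series", "measured", "known", "first", "only" and "open" are said of these compounds alone.

Measured so far:
compound 1 `CC1=CCC[C@H]2[C@](C)(CC3=CC(=O)C=C(N[C@@H](C(=O)O)C(C)C)C3=O)[C@@H](C)CC[C@]12C` gives 10900 nM in a functional assay on HeLa cells (Homo sapiens) for cytotoxicity, read by MTT assay, with a stated time of 72 h; on this read-out higher numbers stand for weaker inhibition and lower numbers for stronger inhibition
compound 2 `CC(C)(C)C1=CC(=O)C=C(NCCC(=O)O)C1=O` gives 47100 nM in this assay

Among the compounds with values here, compound 1 holds the lower of the two numbers in this assay; the gap from compound 1 up to compound 2 lies beyond the usual scatter, though the two compounds differ in more than one place and no single step links them.

Compound 3 `CC1=CCC[C@H]2[C@](C)(CC3=CC(=O)C=CC3=O)[C@@H](C)CC[C@]12C` is not yet measured. It differs from compound 1 in one place: hydrogen in place of (1-carboxy-2-methylpropyl)amino on a double-bonded ring carbon. Within the data shown here, no measured pair shows this change, and compound 2 carries a different core, giving no guide. The direction of the step is uncertain. The step from compound 1 to compound 3 is expected to be a 1.8-fold lower number from compound 1 to compound 3 (0.26 log units; within the scatter), a modest move, probably toward a lower number but possibly none beyond the scatter.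

For compound 3 in this assay the estimate is 6000 nM. The expected range for compound 3 runs from 1500 nM to 25000 nM.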

Compound 3, half-maximal inhibitory concentration: 18100 nM
Compound 3: the middle estimate sits 3.0-fold (0.48 log units) below what was measured, and the stated range covers the measured number.
By their numbers in this assay, from the lowest: compounds 1 and 3 (each within the scatter of the next); then compound 2.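

Hydrogen in place of (1-carboxy-2-methylpropyl)amino on a double-bonded ring carbon gives a 1.7-fold higher number from compound 1 to compound 3 (0.22 log units; within the scatter) in this assay and is the first single-place comparison in the series. On the core of compound 1, the whole group, with its carboxylic acid and defined stereocentre, can therefore be absent at this position with the two numbers remaining within the scatter of each other. No measurement available here bears on what lies behind this result.

Still open, as far as these compounds go, is whether another group at this position, such as a simple primary amine, a methyl ester of the carboxylic acid or an amino acid with a longer chain, would move the number beyond the scatter. Also open, from the compounds shown here alone, is whether the same change would behave alike on the core of compound 2.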